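Two para-halophenyl analogues and an ortho-methoxyphenyl newcomer

This account rests on a few compounds, and the source may have more. Where it says the series, first, only, none or still open, it means among the compounds named here.

Compound 1 `Clc1ccc(-c2cn3ccnc3c(-c3ccc4ncn(C5CCCCC5)c4c3)n2)cc1` and compound 2 `Brc1ccc(-c2cn3ccnc3c(-c3ccc4ncn(C5CCCCC5)c4c3)n2)cc1` share a core and differ only in the halogen on the pendant phenyl ring. In a functional assay on NCI-H460 cells (Homo sapiens) for inhibition, read by sulforhodamine B assay, with a stated time of 48 h, tested at 10 uM (on this read-out lower numbers stand for less inhibition and higher numbers for more inhibition at the one concentration tested (going by the name of the read-out)), compound 1 gives 4.14%, and compound 2 gives 13.2%; the step of a number 9.1 percentage points higher from compound 1 to compound 2 (within the scatter) lies within the scatter, so the two numbers cannot be told apart with confidence, and compound 2 simply stands at the upper of the two numbers without being separated from compound 1.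

Compound 3 `COc1ccccc1-c1cn2ccnc2c(-c2ccc3ncn(C4CCCCC4)c3c2)n1` is not yet measured. It differs from compound 2 by 2-methoxyphenyl in place of 4-bromophenyl on an aromatic carbon. Within the data shown here, no measured step bears directly on this change: the only step available, from compound 1 to compound 2, swaps one halogen for another and stays within the scatter, and nothing in the data tells how a 2-methoxyphenyl behaves in this assay. The step of a number 3.2 percentage points lower from compound 2 to compound 3 (within the scatter) is therefore expected to be no larger than the scatter, though the range must stay wide. Compound 3 is estimated at 10%, within a range from 0% to 35%.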

Compound 3, a percentage reported as inhibition, at one concentration (the size of the read-out at that concentration, not a potency): 9.62%
Compound 3: middle estimate off by 0.4 percentage points, on the high side; measured number inside the range.
By their numbers in this assay, from the lowest: compounds 1, 3 and 2 (each within the scatter of the next).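

In this assay, 2-methoxyphenyl in place of 4-bromophenyl gives a number 3.6 percentage points lower from compound 2 to compound 3 (within the scatter), and 2-methoxyphenyl in place of 4-chlorophenyl gives a number 5.5 percentage points higher from compound 1 to compound 3 (within the scatter). The earlier pair showed only that one halogen could be exchanged for another without a separable result; these steps extend that to a quite different group, which carries oxygen and a hydrogen-bond acceptor and has its substituent at another place on the phenyl ring. At this position on the shared core, therefore, all three groups give numbers that cannot be told apart at the one concentration tested, and nothing available explains why they sit so close together.

Because the new group differs from the halophenyl groups in both the kind of substituent and its place on the phenyl ring, these compounds cannot show whether either difference matters alone or whether the two offset each other. They also leave open whether a phenyl ring bearing an amine or a carboxylic acid would give a number beyond the scatter from these three.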